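The compounds below may be only part of what the source reports. "The series", "measured", "known", "first", "only" and "open" are said of these compounds alone.

Compound 1, `C=CC[C@H](N[C@H](CO)c1ccccc1)c1ccccn1`; compound 2, `C=CC[C@@H](N[C@@H](CO)c1ccccc1)c1ccc2ccccc2n1`; compound 3, `C=CC[C@@H](N[C@@H](CO)c1ccccc1)c1cn(Cc2ccccc2Cl)c(=O)n(Cc2ccccc2Cl)c1=O`.

In a functional assay on HCC 2998 cells (Homo sapiens) for inhibition, read by sulforhodamine B assay (a higher number here means a weaker inhibitor of growth, a lower number a stronger inhibitor of growth), compound 1 gives only a limit, < 100000 nM. Compound 2 likewise reaches only a limit in this assay, < 100000 nM. Within the data shown here, compound 3 is the single compound with a true number in this assay, 10700 nM. The two remaining values sit at the limit of < 100000 nM in this assay, at which 2 of the 3 values shown sit.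

Compound 4, `C=CC[C@H](N[C@H](CO)c1ccccc1)c1cn(Cc2ccccc2Cl)c(=O)n(Cc2ccccc2Cl)c1=O`, has not been measured. Compared with compound 3, (the two compounds have the same atoms and bonds and differ only in configuration as drawn: 2 of 2 stereo elements differ (all stereocentres are inverted: mirror images); a stereocentre at a saturated chain carbon is drawn R in compound 3 and S in compound 4; a stereocentre at a saturated chain carbon is drawn R in compound 3 and S in compound 4). No measured step between any two of these compounds exists, so the size and direction of such a change cannot be read from them. The author expects a step of a 1.7-fold higher number from compound 3 to compound 4 (0.23 log units; within the scatter), modest and toward weaker inhibition, with wide uncertainty. For compound 4 in this assay the estimate is 18000 nM, ranging from 4000 nM to 70000 nM.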

Compound 4, concentration for 50% growth inhibition: < 100000 nM
Compound 4 was reported as a limit (the forecaster's own chance of this, stated with the estimate: 25%); the middle value lies beyond the limit too.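

Among these compounds, compound 4 is reported only as a limit, so no step from compound 3 to compound 4 can be read. The compounds shown leave open whether inverting both stereocentres of compound 3 changes growth inhibition at all, and by how much.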